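The source may report more compounds than this note shows. Statements on the series, on what has been measured and on what is new or still open speak of the compounds shown alone.

In a functional assay on the whole organism (strain Sprague-Dawley) for inhibition, with Rattus norvegicus as the target, with a stated time of 10 min (on this read-out higher numbers stand for an effect only at larger amounts of compound and lower numbers for an effect already at smaller amounts), compound 1 (`CCOC(=O)c1cnc(-c2cc(Cl)ccc2OCC)[nH]c1=O`) gives 0.5 mg/kg and compound 2 (`CCOC(=O)c1cnc(-c2cc(OC)ccc2OCC)[nH]c1=O`) gives 0.3 mg/kg. For the measured compounds named here, these are the only two numbers so far and they lie within the usual scatter of each other, so neither can be placed ahead of the other. Compound 3 (`CCOC(=O)c1cnc(-c2cc([N+](=O)[O-])ccc2OCC)[nH]c1=O`) keeps the shared core and changes one group: nitro in place of methoxy on an aromatic carbon, para to an ethoxy group (nitro in place of methoxy on an aromatic carbon). Going by the values given here, the only measured step at this place is the exchange of chloro for methoxy, a 1.7-fold lower number from compound 1 to compound 2 (0.22 log units; within the scatter). Among the compounds with values here, that single step is small, and no nitro compound has a number yet, so no step beyond the scatter is expected in this assay. The expected step is a 1.3-fold higher number from compound 2 to compound 3 (0.12 log units; within the scatter). For compound 3 the estimated value is 0.4 mg/kg, with an expected range from 0.12 mg/kg to 1.3 mg/kg.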

Compound 3, dose for 50% inhibition: 5 mg/kg
The estimate for compound 3 lay 13-fold (1.10 log units) below the measured number; the whole stated range lies below it.
By their numbers in this assay, from the lowest: compounds 2 and 1 (each within the scatter of the next); then compound 3.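

In this assay, this place on the ring proves sensitive to the group it carries: nitro in place of methoxy gives a 17-fold higher number from compound 2 to compound 3 (1.22 log units; beyond the scatter) and nitro in place of chloro gives a 10-fold higher number from compound 1 to compound 3 (1.00 log units; beyond the scatter) while compound 1 and compound 2 stay within the scatter of each other. The earlier pair could not show this, since only with nitro does a step go beyond the scatter, and here a larger dose is needed than with either chloro or methoxy. Nothing measured here accounts for the size of this step.

The compounds shown leave open how an amine, a hydroxyl or a carboxylic acid would behave at this place, and so whether nitro stands alone among such groups. They also leave open whether the step would be as large with a longer chain in place of the ethoxy group.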